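Halogen Swap on the Indole: Chloro to Bromo

The source may report more compounds than this note shows. Statements on the series, on what has been measured and on what is new or still open speak of the compounds shown alone.

Compound 1 `CO[C@@H]1[C@H](N(C)c2ncc(-c3c[nH]c4ccc(F)cc34)s2)C[C@H]2O[C@]1(C)n1c3ccccc3c3c4c(c5c6ccccc6n2c5c31)C(=O)NC4`: > 10000 nM
Compound 2 `CO[C@@H]1[C@H](N(C)c2ncc(-c3c[nH]c4ccc(Cl)cc34)s2)C[C@H]2O[C@]1(C)n1c3ccccc3c3c4c(c5c6ccccc6n2c5c31)C(=O)NC4`: > 10000 nM

Both values come from a functional assay on K562 cells (Homo sapiens) for antiproliferative activity, read by CellTiter-Glo, with a stated time of 72 h; on this read-out higher numbers stand for weaker inhibition and lower numbers for stronger inhibition. For compound 1 the value is a limit of the assay, > 10000 nM. For compound 2 the value is likewise a limit, > 10000 nM. The step that the two limits leave unreadable from compound 1 to compound 2 thus has no readable size. Where compound 2 stands can only be given as that limit; as the limit of > 10000 nM in this assay, at which 2 of the 2 values shown sit, shows, every value here sits at it.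

Compound 3 `CO[C@@H]1[C@H](N(C)c2ncc(-c3c[nH]c4ccc(Br)cc34)s2)C[C@H]2O[C@]1(C)n1c3ccccc3c3c4c(c5c6ccccc6n2c5c31)C(=O)NC4` differs from compound 2 by bromo in place of chloro on an aromatic carbon. Among the measured compounds shown here, the only measured step that bears on this change is a step that the two limits leave unreadable from compound 1 to compound 2, and its size is not readable. The expectation for compound 3 in this assay is a value that again reaches the limit. Compound 3 is therefore estimated at 20000 nM, within 8000 nM to 60000 nM. The step expected from compound 2 to compound 3, a step that the limit leaves unreadable from compound 2 to compound 3, is none beyond the scatter.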

Compound 3, half-maximal inhibitory concentration: > 10000 nM
Compound 3 was reported as a limit; the forecaster's own chance of this, stated with the estimate: 85%; the middle value does not contradict the limit.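

Compound 3 gives > 10000 nM as a limit of the assay. Among the compounds shown here, no new step among compound 1, compound 2 and compound 3 can be read, as all three values are limits: the limit of > 10000 nM in this assay, at which 3 of the 3 values shown sit.

The compounds shown leave open how fluoro, chloro and bromo on the indole compare in this assay and what value each compound would reach.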